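A few compounds are considered here, and "the series" means these few. Any claim that something is new, unique, unknown or untested is made for them only; others in the source may bear on it.

Working notes on the carbamate series.

Three compounds have numbers in an assay (strain Wistar) for inhibition of Fatty-acid amide hydrolase 1 (Rattus norvegicus); on this read-out lower numbers stand for stronger inhibition and higher numbers for weaker inhibition. Compound 1 `O=C(NC1CCCCC1)Oc1cccc(C(=O)c2nc3ccccc3o2)c1` gives 47 nM. Compound 2 `CCCCNC(=O)Oc1cccc(C(=O)c2nc3ccccc3s2)c1` gives 103 nM. Compound 3 `O=C(NC1CCCC1)Oc1ccc(C(=O)c2nc3ccccc3o2)cc1` gives 288 nM. Within this set compound 3 holds the highest number: the gap to compound 2 is beyond the scatter, and the gap to compound 1 is wider still and also beyond the scatter. Compound 3 also differs from the other two in more than one place, so none of these gaps can be read as the effect of a single change.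

Compound 4 `Cc1ccccc1CNC(=O)Oc1ccc(C(=O)c2nc3ccccc3o2)cc1` has not yet been measured in this assay. It differs from compound 3 in one place: 2-methylbenzyl in place of cyclopentyl on an amide-type nitrogen. Within the data shown here, no pair of measured compounds isolates a change of this kind, so the size of the step rests on the values of the measured compounds alone and on nothing more.

The expectation is that the number for compound 4 remains close to that of compound 3, with the step from compound 3 to compound 4 estimated as a 1.0-fold higher number from compound 3 to compound 4 (0.02 log units; within the scatter), that is, no movement beyond the scatter in either direction. On this basis compound 4 is estimated at 300 nM, with a range from 80 nM to 1200 nM.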

Compound 4, half-maximal inhibitory concentration: 137 nM
Compound 4: the middle estimate sits 2.2-fold (0.34 log units) above what was measured, and the stated range covers the measured number.
By their numbers in this assay, from the lowest: compound 1; then compounds 2 and 4 (each within the scatter of the next); then compound 3.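

In this assay, among these compounds, this is the first step that isolates a single change: with the rest of compound 3 held fixed, 2-methylbenzyl in place of cyclopentyl on the amide-type nitrogen gives a 2.1-fold lower number from compound 3 to compound 4 (0.32 log units; beyond the scatter), a modest move that still lies beyond the scatter. The position therefore accepts an exchange of a five-membered non-aromatic ring of 5 heavy atoms for a group of 8 heavy atoms carrying a six-membered aromatic ring, with no loss of inhibition and a small gain on this read-out. No measurement shown bears on why the number moves.

The step changes ring type, atom count and the methyl substituent all at once, so the compounds shown cannot say which of these carries it; unsubstituted benzyl or 2-phenylethyl on the same nitrogen would begin to separate them. Among the compounds shown here, it also remains open whether the same exchange gives a step of similar size on the core of compound 1, where no single-change pair is available.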